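The source may hold more compounds than are shown below. What is called first, only, known or untested is meant among the compounds shown, and "the series" means these compounds.

Compound 2 `COC(=O)C(O)Cn1cnc2c(N)ncnc21` is tested in a functional assay on PRK cells (Oryctolagus cuniculus) for cytotoxicity; a higher number here means that more compound is tolerated, a lower number that less compound is tolerated. In this assay compound 2 gives > 400 ug/mL, which is a limit of the assay rather than a number. Compound 1 `COCCOC(=O)C(O)Cn1cnc2c(N)ncnc21` gives > 400 ug/mL in this assay, again a limit. The step that the two limits leave unreadable from compound 1 to compound 2 cannot be read because of the limit of > 400 ug/mL in this assay, at which 2 of the 2 values shown sit. Compound 3 `CCCCCOC(=O)C(O)Cn1cnc2c(N)ncnc21` differs from compound 2 by butyl in place of hydrogen on a saturated chain carbon bound to an oxygen next to a carbonyl group. Since no measured step can be read, no shift beyond the scatter is expected in either direction. Compound 3 is expected at 400 ug/mL, between 200 ug/mL and 800 ug/mL. The step of a number no higher from compound 2 to compound 3 (the limit leaves the size open) is estimated to stay within the scatter.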

Compound 3, minimum cytotoxic concentration: 200 ug/mL
Compound 3: middle estimate off by 2.0-fold (0.30 log units), on the high side; the range from low to high includes it.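

Butyl in place of hydrogen at this position gives the first reading in this assay that is a number and not a limit, with an at least 2.0-fold lower number from compound 2 to compound 3 (0.30 log units; that floor lies within the scatter). Measured against the methoxymethyl-bearing compound, the result is an at least 2.0-fold lower number from compound 1 to compound 3 (0.30 log units; that floor lies within the scatter). Neither floor shows a change beyond the scatter, and neither these steps' full size nor the step from compound 1 to compound 2 can be read: the limit of > 400 ug/mL in this assay, at which 2 of the 3 values shown sit.

As far as these compounds go, whether a longer chain such as octyl, or an amine or a carboxylic acid in place of butyl, would give a number clearly beyond the scatter stays open.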